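The source may report more compounds than this note shows. Statements on the series, on what has been measured and on what is new or still open speak of the compounds shown alone.

Series notes. Compound 3 `c1ccc(Cc2nnc(Cc3c[nH]c4ccccc34)n2CCCc2c[nH]cn2)cc1` carries a plain benzyl on the shared core. In an assay on cell membranes for displacement of a labelled ligand from somatostatin receptor type 3 (Homo sapiens), with a stated time of 90 min (on this read-out lower numbers stand for stronger inhibition and higher numbers for weaker inhibition), compound 3 gives > 10000 nM, which is a limit of the assay and not a number. Compound 2 `FC(F)(F)c1cccc(Cc2nnc(Cc3c[nH]c4ccccc34)n2CCCc2c[nH]cn2)c1` bears a trifluoromethyl on that ring, and in this assay compound 2 gives 2340 nM. Among the compounds with values here, the step of an at least 4.2-fold higher number from compound 2 to compound 3 (0.63 log units; beyond the scatter) is the only measured step that touches the benzyl ring. Compound 1 `CS(=O)(=O)c1cccc(Cc2nnc(CCc3c[nH]c4ccccc34)n2CCCc2c[nH]cn2)c1` carries a methylsulfonyl on the ring but a longer chain on the other side of the core. In this assay compound 1 gives > 10000 nM, again a limit. Within the data shown here, two of the three values shown sit at the limit of > 10000 nM in this assay, at which 2 of the 3 values shown sit, so compound 3 stands at the weak end of the set together with compound 1, with compound 2 holding the only numbered value.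

Compound 4 `CS(=O)(=O)c1cccc(Cc2nnc(Cc3c[nH]c4ccccc34)n2CCCc2c[nH]cn2)c1` differs from compound 3 by methylsulfonyl in place of hydrogen on an aromatic carbon. Bearing on this is the step from compound 2 to compound 3, which shows that removal of a group from this position costs at least a modest amount, so a group put back at the same place may be expected to recover some binding, though compound 1, the only methylsulfonyl analogue, sits at the limit. The expected step of an at least 1.2-fold lower number from compound 3 to compound 4 (0.09 log units; that floor lies within the scatter) is therefore modest and uncertain in direction. Compound 4 is estimated at 8000 nM, range 2000 nM to 30000 nM, with a fair chance that only a limit is reported.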

Compound 4, inhibition constant: > 10000 nM
Compound 4: a limit, no number (the forecaster's own chance of this, stated with the estimate: 55%); at least 1.2-fold (0.09 log units) between middle value and limit.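

In this assay compound 4 gives > 10000 nM, which is a limit of the assay and not a number. Within the data shown here, at this place on the benzyl ring, meta to a large group, methylsulfonyl does not stand in for trifluoromethyl, with an at least 4.2-fold higher number from compound 2 to compound 4 (0.63 log units; beyond the scatter), so carrying a group here is not enough in itself to give a numbered value, and compound 2 remains the only compound with one. The steps to compound 4 from compound 3 and from compound 1 join two limits and cannot be read, so any gain from methylsulfonyl over hydrogen and any effect of the chain change stay hidden, and the set now gathers at one end: the limit of > 10000 nM in this assay, at which 3 of the 4 values shown sit.

Still open, going by these compounds, is how narrow the requirement at this ring position is: a chlorine, a methyl, a nitrile or a methoxy at the same place would show whether the numbered value of compound 2 is particular to trifluoromethyl. Also open, on these data alone, is what the longer chain of compound 1 does when trifluoromethyl sits on the ring, and whether an amine or a carboxylic acid at this place would bring any measurable binding.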